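Ketoacid in place of ketoamide in a calpain dipeptide

A few compounds are considered here, and "the series" means these few. Any claim that something is new, unique, unknown or untested is made for them only; others in the source may bear on it.

Compound 1 `CCOC(=O)C(=O)C(CC)NC(=O)C(CC(C)C)NC(=O)OCC(C)C`: 17000 nM
Compound 2 `CCOC(=O)C(=O)[C@H](CC)NC(=O)[C@H](CC(C)C)NC(=O)[C@H](CC(C)C)NS(=O)(=O)c1ccc2ccccc2c1`: 1400 nM
Compound 3 `CCC(NC(=O)C(CC(C)C)NC(=O)OCc1ccccc1)C(=O)C(=O)NCC1CCCCC1`: 44 nM

In an assay on isolated protein (Oryctolagus cuniculus) for inhibition of Calpain-2 catalytic subunit (Homo sapiens), at pH 8.0 (on this read-out lower numbers stand for stronger inhibition and higher numbers for weaker inhibition), compound 3 gives 44 nM, the lowest of the three numbers; compound 2 stands higher at 1400 nM, and compound 1 higher still at 17000 nM, both gaps beyond the scatter. Compound 4 `CCC(NC(=O)C(CC(C)C)NC(=O)OCc1ccccc1)C(=O)C(=O)O` differs from compound 3 in one place: hydroxy in place of (cyclohexylmethyl)amino on a carbonyl carbon. Going by the values given here, no measured pair in this set shows the effect of such a change, so the expectation rests on the set as a whole, in which compound 3 stands alone as the strongest. The expected step from compound 3 to compound 4 is estimated at a 14-fold higher number from compound 3 to compound 4 (1.13 log units; beyond the scatter), towards weaker inhibition and beyond the scatter. Compound 4 is therefore expected to give 600 nM, with a range from 100 nM to 5000 nM.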

Compound 4, inhibition constant: 22 nM
The estimate for compound 4 lay 27-fold (1.44 log units) above the measured number; the whole stated range lies above it.
By their numbers in this assay, from the lowest: compounds 4 and 3 (each within the scatter of the next); then compound 2; then compound 1.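

In this assay the change reads as a 2.0-fold lower number from compound 3 to compound 4 (0.30 log units; within the scatter) and so shows that, on this carbonyl carbon, (cyclohexylmethyl)amino can give way to hydroxy without the number moving beyond the scatter. The six-membered ring of carbon is therefore not required at this position for a number at the level of compound 3. Nothing measured here accounts for the two groups reading alike. Left open is how a plain amino group or methylamino on this carbonyl carbon would read, and whether benzylamino would match either compound.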